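The source may hold more compounds than are shown below. What is called first, only, known or untested is meant among the compounds shown, and "the series" means these compounds.

Compound 2 `CCNC(=O)c1cc(-c2ccc(NS(=O)(=O)c3cccc(Cl)c3Cl)cc2)nc2[nH]ncc12` carries an ethyl group on its amide nitrogen. In an assay for inhibition of serine/threonine-protein kinase Sgk1 (Homo sapiens), with stated times of 30 min and 60 min, in the presence of a further agent that is not named here (on this read-out lower numbers stand for stronger inhibition and higher numbers for weaker inhibition), compound 2 gives only a limit, < 1920 nM. Compound 1 `O=C(NC1CCN(C2CC2)C1)c1cc(-c2ccc(NS(=O)(=O)c3cccc(Cl)c3Cl)cc2)nc2[nH]ncc12`, which bears a 1-cyclopropylpyrrolidin-3-yl group on the same amide nitrogen, gives 610 nM. The step that the limit leaves unreadable from compound 1 to compound 2 cannot be sized because of the limit of < 1920 nM in this assay, at which 1 of the 2 values shown sits. Compound 3 `CN(C)CCCNC(=O)c1cc(-c2ccc(NS(=O)(=O)c3cccc(Cl)c3Cl)cc2)nc2[nH]ncc12` differs from compound 2 by (dimethylamino)methyl in place of hydrogen on a saturated chain carbon, two bonds along the chain from an amide-type nitrogen, so that the ethyl amide becomes a 3-(dimethylamino)propyl amide. For the measured compounds named here, no measured step covers this particular change, and the one measured step in the set is itself unreadable, so the expectation can rest only on where the two known values sit. Compound 3 is expected near 800 nM, within a range from 250 nM to 2500 nM. The step from compound 2 to compound 3 is estimated at a step that the limit leaves unreadable from compound 2 to compound 3, a change that cannot be called clear against a limit.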

Compound 3, half-maximal inhibitory concentration: 633 nM
Beside the measured number, compound 3's estimate is 1.3-fold (0.10 log units) above it, and the stated range covers the measured number.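

In this assay, putting 3-(dimethylamino)propyl in place of 1-cyclopropylpyrrolidin-3-yl on the amide nitrogen gives a 1.0-fold higher number from compound 1 to compound 3 (0.02 log units; within the scatter). For the compounds shown here, for these two compounds, then, a chain with no ring matches the 1-cyclopropylpyrrolidin-3-yl group within the scatter, a comparison the earlier compounds could not offer. Compound 2 gives only a limit, so the steps that touch it cannot be read: the limit of < 1920 nM in this assay, at which 1 of the 3 values shown sits.

Going by these compounds, it therefore stays open whether the dimethylamino group itself matters at this position or whether a chain of this length is enough. A 3-methoxypropyl amide, a 3-carboxypropyl amide or a longer 4-(dimethylamino)butyl amide would each put a different answer to that question in this assay.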